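Hydroxy for dimethylamino on compound 1

This account rests on a few compounds, and the source may have more. Where it says the series, first, only, none or still open, it means among the compounds named here.

For the measured compounds named here, in a functional assay on A549 cells (Homo sapiens) for inhibition, read by sulforhodamine B assay (on this read-out higher numbers stand for weaker inhibition of growth and lower numbers for stronger inhibition of growth), compound 1 `Cc1ccc2[nH]c(-c3ccc(-c4ccc(-c5ccc(N(C)C)cc5)cc4)cc3)nc2c1` gives 3510 nM, the lower of the two numbers so far, and compound 2 `CN(C)c1ccc(-c2ccc(-c3ccc(-c4nc5c(O)cccc5[nH]4)cc3)cc2)cc1` gives 7100 nM. Compound 3 `Cc1ccc2[nH]c(-c3ccc(-c4ccc(-c5ccc(O)cc5)cc4)cc3)nc2c1` is still unmeasured. It carries hydroxy in place of dimethylamino on an aromatic carbon, para to a large group (hydroxy in place of dimethylamino on an aromatic carbon). Going by the values given here, the only measured step, a 2.0-fold higher number from compound 1 to compound 2 (0.31 log units; beyond the scatter), is modest and exchanges 5-methyl-1H-benzimidazol-2-yl for 4-hydroxy-1H-benzimidazol-2-yl, elsewhere in the molecule, so it bears on this change only indirectly. Among the compounds with values here, no measured step touches dimethylamino. Within the data shown here, a step of similar modest size is expected in this assay, leaning weakly toward a higher number, a lean resting solely on compound 2, the one measured compound with a hydroxy group, at 7100 nM. The estimated step is a 1.6-fold higher number from compound 1 to compound 3 (0.20 log units; within the scatter). For compound 3 the estimated value is 5500 nM, with an expected range of 1800 nM to 16000 nM.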

Compound 3, concentration for 50% growth inhibition: 3520 nM
Estimate against measurement, compound 3: 1.6-fold (0.19 log units) above; the range from low to high includes it.
By their numbers in this assay, from the lowest: compounds 1, 3 and 2 (each within the scatter of the next, the first and the last beyond it).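

In this assay, for the compounds shown here, hydroxy in place of dimethylamino on an aromatic carbon, para to a large group, gives a 1.0-fold higher number from compound 1 to compound 3 (0.00 log units; within the scatter) and provides the first direct reading at this position. Going from 3 heavy atoms to 1 and from 0 hydrogen-bond donors to 1 therefore leaves the number within the scatter in this pair, so this read-out does not separate 4-(dimethylamino)phenyl from 4-hydroxyphenyl on the core of compound 1. No measurement shown accounts for this result.

The compounds shown leave open whether other groups at this place, such as methoxy, a primary amine or a carboxylic acid, would read alike. They also leave open whether the same exchange reads alike on the 4-hydroxy-1H-benzimidazol-2-yl series.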